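Pyrrole carboxylic acid series: paw edema inhibition notes

The source may report more compounds than this note shows. Statements on the series, on what has been measured and on what is new or still open speak of the compounds shown alone.

The series is followed in a functional assay on the whole organism (strain Wistar) for inhibition, with Rattus norvegicus as the target, read by paw edema, with stated times of 30 min and 3 h, at a dose of 200 mg/kg by the oral route; on this read-out lower numbers stand for less inhibition and higher numbers for more inhibition at the one dose given (going by the name of the read-out). Compound 1 `O=C(O)c1cccc(-n2c(-c3ccccc3)cc3c2CCCC3)c1` gives 20% in this assay. Compound 2 `COc1cccc(-c2cc3c(n2-c2ccc(O)c(C(=O)O)c2)CCCC3)c1` gives 20% in this assay, and on the numbers shown compound 2 stands level with compound 1, the two values being within the scatter of each other. Among the compounds with values here, no step between measured compounds that differ in a single place is available, so the size of the change brought by one exchange of a group is not known from the data. Compound 3 `O=C(O)c1cc(-n2c(-c3ccc(Br)cc3)cc3c2CCCC3)ccc1O` is not yet measured and differs from compound 2 in one place: 4-bromophenyl in place of 3-methoxyphenyl on an aromatic carbon. With compound 1 and compound 2 both sitting at the same level, no step beyond the scatter is expected from compound 2 to compound 3 in this assay, and the estimated step is no change at the digits printed from compound 2 to compound 3 (within the scatter). Compound 3 is therefore expected to give about 20% in this assay, with a range from 8% to 35%.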

Compound 3, a percentage reported as inhibition, in the whole organism at one dose (the size of the read-out at that dose, not a potency): 40%
For compound 3 the middle estimate is 20 percentage points below the measured one; measured number above the stated range.
By their numbers in this assay, from the lowest: compounds 1 and 2 (each within the scatter of the next); then compound 3.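

Within the data shown here, the exchange of 3-methoxyphenyl for 4-bromophenyl, on the aromatic carbon next to the ring nitrogen, is the first single-place change available, and in this assay it gives a number 20 percentage points higher from compound 2 to compound 3 (beyond the scatter) as a modest step. This position is therefore not silent: a change here alone, with the rest of compound 2 kept, moves the reading away from the level shared by compound 1 and compound 2. Nothing in the data accounts for the step.

The exchange alters both the substituent and its place on the phenyl ring, so 3-bromophenyl or 4-methoxyphenyl would be needed to separate the two. From the compounds shown here alone, whether other groups at this position, such as 4-chlorophenyl or 4-methylphenyl, reach the level of compound 3 stays open, and a reading at one dose gives no potency.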